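Chloro on the benzyl ring across two amine cores

The source may report more compounds than this note shows. Statements on the series, on what has been measured and on what is new or still open speak of the compounds shown alone.

Compound 1 `CCN(CC)Cc1ccc2nc(NC(=O)N/N=C/c3cn(Cc4ccccc4)c4ccccc34)sc2c1` was tested in a functional assay on MDA-MB-231 cells (Homo sapiens) for cytotoxicity, read by MTT assay, with a stated time of 72 h (on this read-out higher numbers stand for weaker inhibition and lower numbers for stronger inhibition), where compound 1 gives 1470 nM. Compound 2 `CCN(CC)Cc1ccc2nc(NC(=O)N/N=C/c3cn(Cc4ccccc4Cl)c4ccccc34)sc2c1` differs from it by chloro in place of hydrogen on an aromatic carbon; this change gave a 1.6-fold lower number from compound 1 to compound 2 (0.21 log units; within the scatter), and compound 2 gives 900 nM. Compound 3 `CC1CCN(Cc2ccc3nc(NC(=O)N/N=C/c4cn(Cc5ccccc5)c5ccccc45)sc3c2)CC1` carries a different core, the difference being (4-methylpiperidin-1-yl in place of diethylamino on a saturated chain carbon bound to an aromatic carbon); that step was a 1.9-fold higher number from compound 1 to compound 3 (0.29 log units; within the scatter), and compound 3 gives 2850 nM. Compound 4 `CC1CCN(Cc2ccc3nc(NC(=O)N/N=C/c4cn(Cc5ccc(Cl)cc5)c5ccccc45)sc3c2)CC1` has not been measured. It differs from compound 3 by chloro in place of hydrogen on an aromatic carbon. This is the same kind of change as that from compound 1 to compound 2, though the place differs: in compound 2 the chloro sits ortho to a large group, in compound 4 para to a large group. Because the earlier change gave a 1.6-fold lower number from compound 1 to compound 2 (0.21 log units; within the scatter), a step of a 1.6-fold lower number from compound 3 to compound 4 (0.20 log units; within the scatter) is expected. Compound 4 is therefore estimated at 1800 nM in this assay, with a likely range from 900 nM to 3600 nM.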

Compound 4, half-maximal inhibitory concentration: 2850 nM
Compound 4: middle estimate off by 1.6-fold (0.20 log units), on the low side; low and high end bracket the measured number.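

On the core of compound 3 in this assay, 4-chlorobenzyl in place of benzyl gave no change at the digits printed from compound 3 to compound 4 (within the scatter). Set beside the earlier step, the change carries from one core to the other without a detectable difference: the same change on two cores in this assay, a 1.6-fold lower number (0.21 log units; within the scatter) from compound 1 to compound 2 and no change at the digits printed (within the scatter) from compound 3 to compound 4, 1.6-fold (0.21 log units) apart, within the scatter of two such steps This does not show a real effect of chloro on either core, and the two steps differ in both core and place, with the chloro para to a large group only in compound 4.

The compounds shown leave open whether chloro at a single place would act alike on both cores. They also leave open whether another benzyl substituent, such as methoxy or nitrile, or another amine, such as morpholine, would shift the number beyond the scatter.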